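Cyclopropylmethyl ester: swapping furan-3-yl for thiophen-2-yl

This account rests on a few compounds, and the source may have more. Where it says the series, first, only, none or still open, it means among the compounds named here.

Compound 3 `CC1=C(C(=O)OCC2CC2)C(c2ccoc2)NC(=O)N1` gives the lowest number of the three measured compounds in an assay on membranes from HEK293 cells for displacement of a labelled ligand from adenosine receptor A2b (Homo sapiens), read by scintillation counting, with a stated time of 30 min (on this read-out lower numbers stand for stronger inhibition and higher numbers for weaker inhibition), at 426 nM. Among the compounds with values here, compound 1 `CC1=C(C(=O)OCC(C)C)C(c2cccs2)NC(=O)N1` gives 2130 nM and compound 2 `CC1=C(C(=O)OCc2ccccc2)C(c2cccs2)NC(=O)N1` gives 1920 nM; the only single-point step among them, a 1.1-fold lower number from compound 1 to compound 2 (0.05 log units; within the scatter), concerns the ester and not the ring at issue here. Compound 4 `CC1=C(C(=O)OCC2CC2)C(c2cccs2)NC(=O)N1` carries thiophen-2-yl in place of furan-3-yl on a saturated ring carbon. Within the data shown here, no measured step isolates this ring swap, since compounds 1 and 2 differ from compound 3 in the ester as well, so the direction is open. Compound 4 is therefore estimated at 800 nM, with a range from 250 nM to 2500 nM, which would mean a step of a 1.9-fold higher number from compound 3 to compound 4 (0.27 log units; within the scatter) in this assay.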

Compound 4, inhibition constant: 1570 nM
Estimate against measurement, compound 4: 2.0-fold (0.29 log units) below; low and high end bracket the measured number.
By their numbers in this assay, from the lowest: compound 3; then compounds 4, 2 and 1 (each within the scatter of the next).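

In this assay, with the cyclopropylmethyl ester held fixed, thiophen-2-yl on the saturated ring carbon in place of furan-3-yl gives a change beyond the scatter (a 3.7-fold higher number from compound 3 to compound 4 (0.57 log units; beyond the scatter)). With thiophen-2-yl held fixed, the ester changes stay within the scatter (a 1.2-fold lower number from compound 2 to compound 4 (0.09 log units; within the scatter); a 1.4-fold lower number from compound 1 to compound 4 (0.13 log units; within the scatter)), so among these compounds only the ring swap moves the number. Nothing here offers an explanation for the ring effect.

As far as these compounds go, whether furan-3-yl would also lower the number with the esters of compounds 1 and 2 remains open. So does the outcome with furan-2-yl or a longer chain on that ring carbon.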